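The source may hold more compounds than are shown below. What is called first, only, known or untested is meant among the compounds shown, and "the series" means these compounds.

The three measured compounds share one core and differ only in what sits on the chain carbon bound to the carbonyl of the amide. Compound 1 `Cn1c(-c2ccc(NC(=O)CCl)cc2)nc(-c2ccccc2)c1-c1ccccc1` carries a chloro there; in a functional assay on MCF7 cells (Homo sapiens) for cytotoxicity, read by MTT assay, with a stated time of 24 h, tested at 16 ug/mL (a lower number here means a weaker effect, a higher number a stronger effect of the compound at the concentration tested), compound 1 gives 15.2%. Compound 2 `Cn1c(-c2ccc(NC(=O)CSc3nc4ccccc4o3)cc2)nc(-c2ccccc2)c1-c1ccccc1` gives 56%, a change of a number 40.8 percentage points higher from compound 1 to compound 2 (beyond the scatter). Compound 3 `Cn1c(-c2ccc(NC(=O)CSc3nc4cc(Cl)ccc4o3)cc2)nc(-c2ccccc2)c1-c1ccccc1` gives 40%, reached by a number 24.8 percentage points higher from compound 1 to compound 3 (beyond the scatter); it stands second highest of the three numbers, separated from compound 2 by a number 16 percentage points lower from compound 2 to compound 3 (beyond the scatter). Compound 4 `Cc1ccc2oc(SCC(=O)Nc3ccc(-c4nc(-c5ccccc5)c(-c5ccccc5)n4C)cc3)nc2c1` is yet to be measured and differs from compound 3 by methyl in place of chloro on an aromatic carbon. For the measured compounds named here, no measured step exchanges a methyl for a chloro, so none bears on this change directly; the only step at that aromatic carbon, a number 16 percentage points lower from compound 2 to compound 3 (beyond the scatter), set hydrogen against chloro and was modest. Going by the values given here, with no direct precedent, compound 4 is expected to move by a number 4 percentage points higher from compound 3 to compound 4 (within the scatter), a step not beyond the scatter. The value of compound 4 in this assay is estimated at 44%, between 28% and 60%.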

Compound 4, a percentage reported as activity, at one concentration (the size of the read-out at that concentration, not a potency): 40.3%
Compound 4: the middle estimate sits 3.7 percentage points above what was measured; the measured number falls inside the stated range.
By their numbers in this assay, from the lowest: compound 1; then compounds 3 and 4 (each within the scatter of the next); then compound 2.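

In this assay, methyl in place of chloro on this aromatic carbon gives no separable change (a number 0.3 percentage points higher from compound 3 to compound 4 (within the scatter)), so these two substituents cannot be told apart here. Methyl in place of hydrogen gives a step (a number 15.7 percentage points lower from compound 2 to compound 4 (beyond the scatter)) much like that of chloro in place of hydrogen (a number 16 percentage points lower from compound 2 to compound 3 (beyond the scatter)), so the lower number is not peculiar to chloro: with either group on this carbon, the number lies below that of compound 2. The methyl-bearing side chain still stands well clear of the chloro on the chain carbon (a number 25.1 percentage points higher from compound 1 to compound 4 (beyond the scatter)), and nothing available explains any of these steps.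

Going by these compounds, whether any group on this carbon would match or exceed the unsubstituted compound 2 stays open, for instance methoxy, an amine or a carboxylic acid. Also open, on these data alone, is whether the same carbon's neighbours in the six-membered ring would respond alike, since every substituent shown sits at this single place.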